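This account rests on a few compounds, and the source may have more. Where it says the series, first, only, none or still open, it means among the compounds named here.

Compound 1 `CCCCC(CCO)n1cnc2c(OC)ncnc21`: > 50000 nM (a limit)
Compound 2 `CCCCCC(CCO)n1cnc2c(OC)ncnc21`: > 50000 nM (a limit)
Compound 3 `CCCCCCC(CCO)n1cnc2c(Cl)ncnc21`: 11900 nM

All three compounds were tested in a functional assay on HCT-116 cells (Homo sapiens) for antiproliferative activity, read by MTT assay, with a stated time of 48 h; a higher number here means a weaker inhibitor, a lower number a stronger inhibitor. Compound 3 gives 11900 nM. Within the data shown here, that is the only actual number in this small set, since the other two results are limits. Among the measured compounds shown here, the one measured step between neighbours on the chain is a step that the two limits leave unreadable from compound 1 to compound 2, so it offers no size to build on.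

The next compound to be measured is compound 4 `CCCCCCC(CCO)n1cnc2c(OC)ncnc21`. It keeps the chain of compound 3, but methoxy takes the place of chloro on an aromatic carbon: methoxy in place of chloro on an aromatic carbon. For the measured compounds named here, no measured step shows this swap directly, so the evidence is indirect.

Compound 1 and compound 2 both carry methoxy, and their chains differ from that of compound 3. These two compounds share (the limit of > 50000 nM in this assay, at which 2 of the 3 values shown sit). This points towards a weaker result for the methoxy compound in this assay, of moderate but uncertain size, and the result may well be only a limit.

The expected change is a 2.9-fold higher number from compound 3 to compound 4 (0.47 log units; beyond the scatter). For compound 4 the estimated value is 35000 nM, with an expected range from 15000 nM to 80000 nM.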

Compound 4, half-maximal inhibitory concentration: > 50000 nM
Compound 4: a limit, no number; the forecaster's own chance of this, stated with the estimate: 55%; at least 1.4-fold (0.15 log units) between middle value and limit.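

Compound 3 and compound 4 carry the same chain and differ in one place only, on an aromatic carbon next to the ring nitrogen, and in this assay methoxy in place of chloro there gives an at least 4.2-fold higher number from compound 3 to compound 4 (0.62 log units; beyond the scatter). Among these compounds, this is the first direct reading of this swap: with the chain held fixed, the chloro compound is the stronger inhibitor of the pair, a comparison that the earlier compounds, whose chains differ from that of compound 3, could only hint at. Compound 4 gives > 50000 nM, which is a limit and not a number, and so all the methoxy compounds shown now sit at the same limit: the limit of > 50000 nM in this assay, at which 3 of the 4 values shown sit.

The steps from compound 1 and from compound 2 to compound 4 cannot be read, so whether chain length matters among the methoxy compounds stays unknown, and compound 3 is the only chloro compound shown, so the same question is open for chloro. Also open, as far as these compounds go, is how an amine or a bromo group at this aromatic carbon would compare with chloro, and whether chloro on a longer chain would change the result.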